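Chloro in place of trifluoromethyl on compound 1

A few compounds are considered here, and "the series" means these few. Any claim that something is new, unique, unknown or untested is made for them only; others in the source may bear on it.

Values so far in an ADME assay on Vero cells (Chlorocebus sabaeus) for cytotoxicity, with a stated time of 72 h (a higher number here means a weaker inhibitor, a lower number a stronger inhibitor), for the series
- compound 1 `CCOC(=O)c1cc(COc2ccnc3cc(C(F)(F)F)ccc23)on1` gives "not determined" (no result reported)
- compound 2 `CCOC(=O)c1cc(COc2cc(C(F)(F)F)nc3c(C(F)(F)F)cc(OC)cc23)on1` gives > 128000 nM

Compound 1 stands at "not determined" (no result reported) in this assay, so the step below has no measured starting point. The only other entry is a limit of the assay and not a number, with compound 2 at > 128000 nM here. Compound 3 `CCOC(=O)c1cc(COc2ccnc3cc(Cl)ccc23)on1` remains to be measured. The structural change is chloro in place of trifluoromethyl on an aromatic carbon and amounts to chloro in place of trifluoromethyl on an aromatic carbon. Among the measured compounds shown here, with no measured step to go on, no step beyond the scatter is expected in this assay, and no direction is expected. The expectation leans on compound 2 with > 128000 nM as its only anchor, and a limit is a likely report. For compound 3 the estimated value is 100000 nM, with an expected range from 35000 nM to 128000 nM in this series.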

Compound 3, half-maximal inhibitory concentration: > 128000 nM
Compound 3: only a limit was reported; the forecaster's own chance of this, stated with the estimate: 60%; middle value at least 1.2-fold (0.10 log units) away from the limit.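

No step can be read between compound 1 and compound 3 in this assay, with compound 1 at "not determined" (no result reported). Compound 3 gives > 128000 nM, which is a limit of the assay and not a number. The compounds shown leave open whether chloro in place of trifluoromethyl shifts the value in this assay.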